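The source may hold more compounds than are shown below. What is called first, only, known or untested is meant among the compounds shown, and "the series" means these compounds.

In a functional assay on U-251 cells (Homo sapiens) for antiproliferative activity, read by MTT assay, with a stated time of 48 h (a higher number here means a weaker inhibitor, a lower number a stronger inhibitor), compound 3 `COc1cc(-c2cccc3nc(-c4cccc(F)c4)oc23)cc(OC)c1OC` gives 2900 nM, and compound 1 `COc1cc(-c2cccc3nc(-c4ccccc4)oc23)cc(OC)c1OC` gives 3500 nM. The two sit level, with a 1.2-fold lower number from compound 1 to compound 3 (0.08 log units; within the scatter) for fluoro in place of hydrogen on an aromatic carbon. For compound 2 `COc1ccc(-c2nc3cccc(-c4cc(OC)c(OC)c(OC)c4)c3o2)cc1` only a limit is reported, > 25000 nM. Compound 4 `COc1cc(-c2cccc3nc(-c4ccc(F)cc4)oc23)cc(OC)c1OC` carries 4-fluorophenyl in place of 3-fluorophenyl on an aromatic carbon. The fluoro step is the closest guide. The methoxy steps, an at least 7.1-fold higher number from compound 1 to compound 2 (0.85 log units; beyond the scatter) and an at least 8.6-fold lower number from compound 2 to compound 3 (0.93 log units; beyond the scatter), are larger and warn of some risk towards higher numbers, though they involve a different group. No shift beyond the scatter is expected in this assay, and the expected change is a 1.1-fold higher number from compound 3 to compound 4 (0.06 log units; within the scatter). Compound 4 is estimated at 3300 nM, with an expected range of 1400 nM to 8000 nM.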

Compound 4, half-maximal inhibitory concentration: > 25000 nM
Compound 4 gave a limit, no number (the forecaster's own chance of this, stated with the estimate: 7%); at least 7.5-fold (0.87 log units) between middle value and limit.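

In this assay, where the fluoro sits on the phenyl matters: 3-fluorophenyl in compound 3 stays level with the plain phenyl of compound 1, yet 4-fluorophenyl brings an at least 8.6-fold higher number from compound 3 to compound 4 (0.93 log units; beyond the scatter) and an at least 7.1-fold higher number from compound 1 to compound 4 (0.85 log units; beyond the scatter). The two compounds shown with a 4-substituted phenyl, compound 2 with 4-methoxyphenyl and compound 4 with 4-fluorophenyl, both end at a limit, not a number: the limit of > 25000 nM in this assay, at which 2 of the 4 values shown sit. The step between those two cannot be read. Open, from the compounds shown here alone, is how far past the limit either compound lies, and whether 4-aminophenyl in the same place also ends there.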